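Switching the vinyl aryl group: thiophene to methoxyphenyl

This account rests on a few compounds, and the source may have more. Where it says the series, first, only, none or still open, it means among the compounds named here.

Compound 1 `Cc1ccsc1/C=C(/SCc1ccc(Cl)cc1)C(=O)c1ccc(Cl)cc1` is one of three congeners sharing a core that carries a benzylthio group on one alkene carbon and a 4-chlorobenzoyl group alongside it. In a functional assay on DU-145 cells (Homo sapiens) for inhibition, read by trypan blue exclusion, with a stated time of 96 h (a lower number here means a stronger inhibitor of growth, a higher number a weaker inhibitor of growth), compound 1 gives 50000 nM. Compound 2 `Cc1ccsc1/C=C(/SCc1ccccc1F)C(=O)c1ccc(Cl)cc1` gives 50000 nM, and the pair sits level: no change at the digits printed from compound 1 to compound 2 (within the scatter). Compound 3 `Cc1ccc(CS/C(=C/c2sccc2C)C(=O)c2ccc(Cl)cc2)cc1` gives 10000 nM, the lowest of the three numbers; the step of a 5.0-fold lower number from compound 1 to compound 3 (0.70 log units; beyond the scatter) and the step of a 5.0-fold lower number from compound 2 to compound 3 (0.70 log units; beyond the scatter) are both modest, and both concern the group on the saturated chain carbon bound to a sulfur. Going by the values given here, compound 1 therefore stands with compound 2 at the top of the three numbers, with compound 3 as the only distinguishable member.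

Compound 4 `COc1ccc(/C=C(/SCc2ccc(Cl)cc2)C(=O)c2ccc(Cl)cc2)cc1` is unmeasured. It differs from compound 1 at a different position: 4-methoxyphenyl in place of 3-methylthiophen-2-yl on a double-bonded chain carbon bound to a double-bonded chain carbon. Among the compounds with values here, none of the measured steps touches this double-bonded chain carbon, so the three steps give no direct guide to its size or direction. The measured steps elsewhere in the series stay within a modest span, so a step of similar or smaller size is expected here, with no firm direction; the expected step is a 1.4-fold lower number from compound 1 to compound 4 (0.15 log units; within the scatter). For compound 4 in this assay the estimate is 35000 nM, with a range from 10000 nM to 100000 nM.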

Compound 4, concentration for 50% growth inhibition: 10000 nM
Estimate against measurement, compound 4: 3.5-fold (0.54 log units) above; low and high end bracket the measured number.
By their numbers in this assay, from the lowest: compounds 3 and 4 (each within the scatter of the next); then compounds 1 and 2 (each within the scatter of the next).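

Going by these compounds alone, this position is not silent: in this assay, 4-methoxyphenyl in place of 3-methylthiophen-2-yl on a double-bonded chain carbon bound to a double-bonded chain carbon gives a 5.0-fold lower number from compound 1 to compound 4 (0.70 log units; beyond the scatter), the first measured step at this place. Within the data shown here, the step shows that the 3-methylthiophen-2-yl group is not required for growth inhibition at this level, as a six-membered aromatic ring of carbon only serves here, with the counts of hydrogen-bond donors and acceptors the same for the two groups; the single step from compound 1 at the other changed place, a 5.0-fold lower number from compound 1 to compound 3 (0.70 log units; beyond the scatter), is printed at the same size. No supporting measurement is available to explain the step at this position.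

Among these compounds, the single exchange changes the ring and adds the methoxy group together, so a plain phenyl group would be needed to tell these two changes apart. Also open, from the compounds shown here alone, is how other groups behave on this ring, such as an amine or a carboxylic acid in place of the methoxy group, and whether the 4-methoxyphenyl step holds when the sulfur-bound chain carries 4-methylphenyl rather than 4-chlorophenyl.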